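Chain and ring variants at one aromatic carbon

The source may hold more compounds than are shown below. What is called first, only, known or untested is meant among the compounds shown, and "the series" means these compounds.

compound 1 `CCCCCc1nc(C(F)(F)F)ccc1CNC(=O)C(C)c1ccc(NS(C)(=O)=O)c(F)c1`: 1 nM
compound 2 `CCC1CC=C(c2nc(C(F)(F)F)ccc2CNC(=O)C(C)c2ccc(NS(C)(=O)=O)c(F)c2)CC1`: 0.1 nM
compound 3 `CC(C(=O)NCc1ccc(C(F)(F)F)nc1C1=CCC(C)(C)CC1)c1ccc(NS(C)(=O)=O)c(F)c1`: 0.2 nM
compound 4 `CCC/C=C\c1nc(C(F)(F)F)ccc1CNC(=O)C(C)c1ccc(NS(C)(=O)=O)c(F)c1`: not yet measured

In an assay on CHO cells for antagonist activity at transient receptor potential cation channel subfamily V member 1 (Homo sapiens), read by FLIPR and calcium flux (on this read-out lower numbers stand for stronger inhibition and higher numbers for weaker inhibition), compound 3 stands second highest of the three numbers. Its nearest neighbour is compound 2, with a 2.0-fold higher number from compound 2 to compound 3 (0.30 log units; within the scatter); its furthest is compound 1, with a 5.0-fold lower number from compound 1 to compound 3 (0.70 log units; beyond the scatter). Compound 4 differs from compound 3 in one place: pent-1-en-1-yl in place of 4,4-dimethylcyclohex-1-en-1-yl on an aromatic carbon. The new group is a five-carbon chain, as in compound 1, but with one double bond outside aromatic rings and no ring.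

The measured steps that bear on this are a 5.0-fold lower number from compound 1 to compound 3 (0.70 log units; beyond the scatter) and a 10-fold lower number from compound 1 to compound 2 (1.00 log units; beyond the scatter); both are modest and beyond the scatter, and in both a six-membered non-aromatic ring in place of the pentyl chain gave the lower number. Among the measured compounds shown here, no measured pair shows what a double bond in an open chain does on its own. Pent-1-en-1-yl shares the chain length of compound 1 and the double bond of the groups in compound 2 and compound 3, so a partial move back toward compound 1 is expected, of about a 2.5-fold higher number from compound 3 to compound 4 (0.40 log units; beyond the scatter). Compound 4 is therefore estimated at 0.5 nM, with a range from 0.15 nM to 2 nM.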

Compound 4, inhibition constant: 2.1 nM
For compound 4 the middle estimate is 4.2-fold (0.62 log units) below the measured one; measured number outside the range, above it.
By their numbers in this assay, from the lowest: compounds 2 and 3 (each within the scatter of the next); then compound 1; then compound 4.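

In this assay, the open pent-1-en-1-yl chain does not keep the low numbers of the ring compounds at this aromatic carbon, with an 11-fold higher number from compound 3 to compound 4 (1.02 log units; beyond the scatter) and a 21-fold higher number from compound 2 to compound 4 (1.32 log units; beyond the scatter), both larger than the steps from the pentyl chain to either ring group; a double bond outside aromatic rings is therefore not enough on its own, and among these compounds the low numbers appear only where it sits in a six-membered non-aromatic ring. Set against the saturated chain of the same length, the double bond moves the number the other way, with a 2.1-fold higher number from compound 1 to compound 4 (0.32 log units; beyond the scatter), a modest step beyond the scatter, so that both open chains stand above compounds 2 and 3. Nothing on hand gives a reason for these differences.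

The ring groups also carry more heavy atoms than either chain, so the ring itself and the added carbons remain unseparated here, and oct-1-en-1-yl, an open chain matching the carbon count of 4,4-dimethylcyclohex-1-en-1-yl, would address that. Equally open, from the compounds shown here alone, is whether the ring needs its double bond at all, a question that a saturated cyclohexyl group would settle.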